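A few compounds are considered here, and "the series" means these few. Any claim that something is new, unique, unknown or untested is made for them only; others in the source may bear on it.

Compound 1 `C/C(=N\Nc1nc(C)cs1)c1ccc(Cl)c(Cl)c1`, with a methyl group on the shared core, gives 26100 nM in an ADME assay on H9c2 cells (Rattus norvegicus) for cytotoxicity, read by resazurin assay, with a stated time of 72 h; on this read-out lower numbers stand for higher toxicity in this test and higher numbers for lower toxicity in this test. Compound 2 `C/C(=N\Nc1nc(-c2ccccc2)cs1)c1ccc(Cl)c(Cl)c1` carries phenyl in that place and reads > 50000 nM, which is a limit. Compound 3 `C/C(=N\Nc1nc(-c2ccc(C)cc2)cs1)c1ccc(Cl)c(Cl)c1` carries 4-methylphenyl and reads > 50000 nM, also a limit, so no exact number is available for it. Replacing the methyl gave an at least 1.9-fold higher number from compound 1 to compound 2 (0.28 log units; that floor lies within the scatter) and an at least 1.9-fold higher number from compound 1 to compound 3 (0.28 log units; that floor lies within the scatter), while adding methyl to the phenyl gave a step that the two limits leave unreadable from compound 2 to compound 3. Compound 4 `C/C(=N\Nc1nc(-c2ccc(Cl)cc2)cs1)c1ccc(Cl)c(Cl)c1` differs from compound 3 by chloro in place of methyl on an aromatic carbon. None of these steps makes this exchange, so no change beyond the scatter is expected in this assay. The expected step is a number no higher from compound 3 to compound 4 (the limit leaves the size open). The estimate for compound 4 is 50000 nM, within a range of 25000 nM to 80000 nM.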

Compound 4, half-maximal cytotoxic concentration: > 50000 nM
Compound 4: no number, only a limit; the forecaster's own chance of this, stated with the estimate: 60%; the middle value sits exactly at the limit.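

In this assay, 4-chlorophenyl on the shared core gives an at least 1.9-fold higher number from compound 1 to compound 4 (0.28 log units; that floor lies within the scatter). Chloro therefore joins hydrogen and methyl as a group on that phenyl that yields no exact number, which is new for this position. The steps among compound 2, compound 3 and compound 4 cannot be read, because all three rest on the same limit: the limit of > 50000 nM in this assay, at which 3 of the 4 values shown sit.

On these data alone, whether an amine or a carboxylic acid in that place on the phenyl would give a readable number stays open. So does whether a longer chain in place of the phenyl would read like compound 1.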